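The source may report more compounds than this note shows. Statements on the series, on what has been measured and on what is new or still open speak of the compounds shown alone.

Compound 1 `CC(C)[C@H](NC(=O)CN(c1nc(Cl)nc2[nH]cnc12)C1CC1)C(=O)OCc1ccccc1` stands highest of the three numbers measured in a functional assay on the whole organism (Tail, strain ICR) with Mus musculus as the target, in the tail flick test, with a stated time of 30 min, at a dose of 25 umol/kg by the oral route (on this read-out higher numbers stand for a stronger effect at the one dose given and lower numbers for a weaker effect), where compound 1 gives 33.4%. Compound 3 `CC(C)[C@H](NC(=O)CN(c1nc(Cl)nc2[nH]cnc12)C1CC1)C(=O)O` gives 31.2% in this assay, and the step of a number 2.2 percentage points lower from compound 1 to compound 3 (within the scatter) lies within the scatter. Compound 2 `CC[C@H](C)[C@H](NC(=O)CN(c1nc(Cl)nc2[nH]cnc12)C1CC1)C(=O)O` gives 30.3%, a number within the scatter of compound 1, and the step of a number 0.9 percentage points higher from compound 2 to compound 3 (within the scatter) is likewise within the scatter. Among the measured compounds shown here, no measured step thus separates the three compounds. Compound 4 `CC(C)C[C@H](NC(=O)CN(c1nc(Cl)nc2[nH]cnc12)C1CC1)C(=O)OCc1ccccc1` differs from compound 1 by isobutyl in place of isopropyl on a saturated chain carbon bound to an amide-type nitrogen and a carbonyl carbon. For the measured compounds named here, the only precedent that also swaps one small alkyl piece for another, the step from compound 2 to compound 3, stayed within the scatter; no measured step bears directly on this change. Compound 4 is therefore expected to show a step of a number 0.4 percentage points lower from compound 1 to compound 4 (within the scatter), nothing beyond the scatter. The estimate for compound 4 is 33%, with a range from 23% to 43%.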

Compound 4, a percentage reported as activity, at one dose (the size of the read-out at that dose, not a potency): 33.9%
Estimate against measurement, compound 4: 0.9 percentage points below, and the stated range covers the measured number.
By their numbers in this assay, from the lowest: compounds 2, 3, 1 and 4 (each within the scatter of the next).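

Isobutyl in place of isopropyl on a saturated chain carbon bound to an amide-type nitrogen and a carbonyl carbon gives, in this assay, a number 0.5 percentage points higher from compound 1 to compound 4 (within the scatter). Among the compounds shown here, this is the first direct reading at this position, and it shows that the larger of these two alkyl groups leaves the number within the scatter while the benzyl group on the oxygen stays in place. Nothing available explains why the number holds.

Going by these compounds, whether a longer chain or an amine at this position would move the number beyond the scatter remains open. So does whether isobutyl would behave the same way with hydrogen in place of that benzyl group.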